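A few compounds are considered here, and "the series" means these few. Any claim that something is new, unique, unknown or untested is made for them only; others in the source may bear on it.

The series shares one core. In an ADME assay on the whole organism (Macaca fascicularis) (on this read-out lower numbers stand for a shorter-lived compound and higher numbers for a longer-lived compound), compound 2 `Cc1ccc(-c2nc(=O)o[nH]2)c(-c2ccc([C@@H](C)N(CC3CC3)c3nc(C(=O)NS(=O)(=O)C4CC4)c(C(C)C)s3)cc2)c1` gives 5.2 h, the second highest of the three measured numbers: compound 3 `Cc1ccc(-c2nc(=O)o[nH]2)c(-c2ccc([C@@H](C)N(CC3CC3)c3nc(C(=O)NS(=O)(=O)C4CC4)c(C4CCC4)s3)cc2)c1` gives 5.7 h and compound 1 `CCc1sc(N(CC2CC2)[C@H](C)c2ccc(-c3cc(C)ccc3-c3nc(=O)o[nH]3)cc2)nc1C(=O)NS(=O)(=O)C1CC1` gives 2.9 h, with a 1.1-fold higher number from compound 2 to compound 3 (0.04 log units; within the scatter) and a 1.8-fold higher number from compound 1 to compound 2 (0.25 log units; within the scatter) both inside the scatter.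

Compound 4 `Cc1ccc(-c2nc(=O)o[nH]2)c(-c2ccc([C@@H](C)N(CC3CC3)c3nc(C(=O)NS(=O)(=O)C4CC4)c(C)s3)cc2)c1` differs from compound 2 by methyl in place of isopropyl on an aromatic carbon. Going by the values given here, two measured steps concern the same aromatic carbon: a 1.1-fold higher number from compound 2 to compound 3 (0.04 log units; within the scatter) and a 2.0-fold higher number from compound 1 to compound 3 (0.29 log units; within the scatter), each within the scatter, and in each the bulkier group sat with the higher number. Given these steps, the smaller methyl is expected to bring compound 4 a somewhat lower number, likely still within the scatter. Compound 4 is estimated at 3.5 h, between 2 h and 6 h. The expected step is a 1.5-fold lower number from compound 2 to compound 4 (0.17 log units; within the scatter).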

Compound 4, mean residence time: 4.2 h
Estimate against measurement, compound 4: 1.2-fold (0.08 log units) below; the measured number falls inside the stated range.
By their numbers in this assay, from the lowest: compounds 1, 4, 2 and 3 (each within the scatter of the next).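

In this assay, methyl on this aromatic carbon next to the ring sulfur stays within the scatter of both larger groups, with a 1.2-fold lower number from compound 2 to compound 4 (0.09 log units; within the scatter) for isopropyl and a 1.4-fold lower number from compound 3 to compound 4 (0.13 log units; within the scatter) for cyclobutyl. The smallest change at this carbon, hydrogen in place of methyl on the saturated chain carbon of the ethyl group, gives a 1.4-fold higher number from compound 1 to compound 4 (0.16 log units; within the scatter), also within the scatter, so methyl, ethyl, isopropyl and cyclobutyl are not separated here. No supporting data explain these numbers.

Open, as far as these compounds go, is whether an amine or a carboxylic acid on this aromatic carbon would give a step beyond the scatter.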